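Opening a Ring on the Sulfonyl Group of Compound 1

The source may hold more compounds than are shown below. What is called first, only, known or untested is meant among the compounds shown, and "the series" means these compounds.

Compound 1 `CCn1c(=O)c2nc(-c3ccc(S(=O)(=O)N4CCOCC4)cc3)[nH]c2n(CC)c1=O` was tested in an assay for binding affinity to adenosine receptor A1 (Bos taurus) (a lower number here means a stronger inhibitor, a higher number a weaker inhibitor), where compound 1 gives 13 nM. Compound 2 `Cc1cccc(-c2nc3c(=O)n(C)c(=O)n(C)c3[nH]2)c1` in this assay gives 13 nM, so the two stand level at the digits shown and compound 1 sits at neither end of what is known. Among the measured compounds shown here, only two compounds have been measured, and no pair of them differs in a single place, so no single step has been recorded. Compound 3 `CCn1c(=O)c2nc(-c3ccc(S(=O)(=O)NCCN(C)C)cc3)[nH]c2n(CC)c1=O` differs from compound 1 by (2-(dimethylamino)ethyl)amino in place of morpholin-4-yl on a sulfonyl sulfur. For the measured compounds named here, with no measured pair to guide the size of this change, the expectation for compound 3 in this assay is a step of a 1.2-fold higher number from compound 1 to compound 3 (0.06 log units; within the scatter) that stays within the usual scatter, with no clear direction. Compound 3 is therefore estimated at 15 nM in this assay, with a likely range from 5 nM to 50 nM.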

Compound 3, half-maximal inhibitory concentration: 3.3 nM
Estimate against measurement, compound 3: 4.5-fold (0.66 log units) above; measured number outside the range, below it.
By their numbers in this assay, from the lowest: compound 3; then compounds 1 and 2 (each within the scatter of the next).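

Moving from a closed ring to an open chain on the sulfonyl sulfur does register in this assay: with the number of heavy atoms unchanged, replacing morpholin-4-yl with (2-(dimethylamino)ethyl)amino brings a 3.9-fold lower number from compound 1 to compound 3 (0.60 log units; beyond the scatter). Among the compounds shown here, this is the first single-place step recorded here, and it shows that this position can shift the reading beyond the usual scatter, although the step is modest. No measurement at hand accounts for the shift.

This one step cannot separate the loss of the ring from the gain of a hydrogen-bond donor or the arrival of the dimethylamino end. On these data alone, it remains open how a piperazin-1-yl ring, a simple ethylamino group or the longer (3-(dimethylamino)propyl)amino chain would compare at this position.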